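Swapping the Methoxyphenyl Ketone for a Difluorophenyl Ketone

The compounds below may be only part of what the source reports. "The series", "measured", "known", "first", "only" and "open" are said of these compounds alone.

Measured in a functional assay on UACC-62 cells (Homo sapiens) for inhibition, read by sulforhodamine B assay, with a stated time of 48 h; a lower number here means a stronger inhibitor of growth, a higher number a weaker inhibitor of growth:
Compound 1 `COc1ccc(C(=O)/C=C/c2cc(-c3cc(OC)c(OC)c(OC)c3)n[nH]2)cc1OC` gives 1740 nM.
Compound 2 `COc1ccc(C(=O)/C=C/c2cc(-c3cc(OC)c(OC)c(OC)c3)n[nH]2)cc1` gives 1850 nM.

Going by the values given here, compound 2 and compound 1 sit within the scatter of each other, the only known step being a 1.1-fold higher number from compound 1 to compound 2 (0.03 log units; within the scatter). Compound 3 `COc1cc(-c2cc(/C=C/C(=O)c3ccc(F)c(F)c3)[nH]n2)cc(OC)c1OC` differs from compound 2 by 3,4-difluorophenyl in place of 4-methoxyphenyl on a carbonyl carbon. Among the compounds with values here, no measured step tests this exchange directly; the single step seen, a 1.1-fold higher number from compound 1 to compound 2 (0.03 log units; within the scatter), changed the same ring and stayed within the scatter. A small step in this assay is therefore expected, with wide uncertainty: the expected step is a 1.1-fold higher number from compound 2 to compound 3 (0.03 log units; within the scatter). Compound 3 is estimated at 2000 nM, in a range from 700 nM to 6000 nM.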

Compound 3, concentration for 50% growth inhibition: 2380 nM
For compound 3 the middle estimate is 1.2-fold (0.08 log units) below the measured one; the range from low to high includes it.
By their numbers in this assay, from the lowest: compounds 1, 2 and 3 (each within the scatter of the next).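

Compound 1 and compound 2 both keep a methoxy group on the ring at the carbonyl carbon, whereas in compound 3 that ring has none, with 3,4-difluorophenyl in its place. In this assay this exchange gives a 1.3-fold higher number from compound 2 to compound 3 (0.11 log units; within the scatter) and a 1.4-fold higher number from compound 1 to compound 3 (0.14 log units; within the scatter) so growth inhibition at this level does not depend on methoxy on this ring. Nothing available here explains this result. On these data alone, whether an amine or a carboxylic acid on this ring would move the number stays open.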